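The source may report more compounds than this note shows. Statements on the series, on what has been measured and on what is new or still open speak of the compounds shown alone.

Measured compounds in an ADME assay on L02 cells (Homo sapiens) for cytotoxicity, read by MTT assay, with a stated time of 48 h; on this read-out lower numbers stand for stronger inhibition and higher numbers for weaker inhibition:
compound 1 `CN(CCC#N)C[C@H]1CN(c2ccc(-n3cc(-c4ccccn4)cn3)c(F)c2)C(=O)O1` gives > 400 ug/mL, a limit of the assay rather than a number.
compound 2 `O=C1CSC(=O)N1C[C@H]1CN(c2ccc(-n3cc(-c4ccccn4)cn3)c(F)c2)C(=O)O1` gives > 400 ug/mL, likewise a limit.
compound 3 `COC[C@H]1CN(c2ccc(-n3cc(-c4ccccn4)cn3)c(F)c2)C(=O)O1` gives > 400 ug/mL, again a limit.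

Compound 3 therefore stands only at the limit of > 400 ug/mL in this assay, at which 3 of the 3 values shown sit, where every value shown sits; no number places it among the others. The steps recorded so far, a step that the two limits leave unreadable from compound 1 to compound 2, a step that the two limits leave unreadable from compound 1 to compound 3 and a step that the two limits leave unreadable from compound 2 to compound 3, all run between limits, so none of them has a readable size. Compound 4 `CCNC(=O)NC[C@H]1CN(c2ccc(-n3cc(-c4ccccn4)cn3)c(F)c2)C(=O)O1` carries the change ((ethylcarbamoyl)amino in place of methoxy on a saturated chain carbon bound to a saturated ring carbon). Within the data shown here, with no step of known size to bear on it, the expected step of a number no higher from compound 3 to compound 4 (the limit leaves the size open) is none beyond the scatter. Compound 4 is thus estimated at 400 ug/mL, with a range from 250 ug/mL to 650 ug/mL, and most likely it too will be reported only as a limit.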

Compound 4, half-maximal inhibitory concentration: > 400 ug/mL
Compound 4: a limit, no number (the forecaster's own chance of this, stated with the estimate: 85%); the middle value lies on the limit itself.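

In this assay, among these compounds, compound 4 is reported only as a limit, as are compound 1, compound 2 and compound 3, so no step to compound 4 can be read: (the limit of > 400 ug/mL in this assay, at which 4 of the 4 values shown sit). The compounds shown leave open where any true value lies and whether changing the group on the saturated chain carbon alters it.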